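Switching a methoxyethyl amide to a pentyl amide

The compounds below may be only part of what the source reports. "The series", "measured", "known", "first", "only" and "open" are said of these compounds alone.

Compound 1, `COc1ccc2nc(C)cc(OCC(=O)Nc3ccccc3)c2c1`: in an ADME assay on HepG2 cells (Homo sapiens) for cytotoxicity, read by trypan blue exclusion, with a stated time of 48 h, in the presence of a further agent that is not named here (on this read-out lower numbers stand for higher toxicity in this test and higher numbers for lower toxicity in this test), compound 1 gives > 155000 nM, which is a limit of the assay.
Compound 2, `COc1ccc2nc(C)cc(OCC(=O)Nc3ccc(Cl)cc3)c2c1`: in this assay compound 2 gives 89900 nM.
Compound 3, `COCCNC(=O)COc1cc(C)nc2ccc(OC)cc12`: in this assay compound 3 gives > 164000 nM, again a limit of the assay.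

Compound 3 therefore stands at the top of the range the numbers reach: its result is a limit, as is that of compound 1, and only compound 2 returns a number. The step of an at least 1.8-fold higher number from compound 2 to compound 3 (0.26 log units; that floor lies within the scatter) has a floor that sits within the scatter, and the step that the two limits leave unreadable from compound 1 to compound 3 cannot be read because both ends are limits (the limit of > 155000 nM in this assay, at which 1 of the 3 values shown sits, (the limit of > 164000 nM in this assay, at which 1 of the 3 values shown sits)).

Compound 4, `CCCCCNC(=O)COc1cc(C)nc2ccc(OC)cc12`, differs from compound 3 in one place: propyl in place of methoxy on a saturated chain carbon, two bonds along the chain from an amide-type nitrogen. Among the measured compounds shown here, none of the measured steps touches the amide substituent in this way; the only ones that change the amide nitrogen, from compound 1 to compound 3 and from compound 2 to compound 3, are at best floors within the scatter. For compound 4 the expected step is an at least 1.0-fold lower number from compound 3 to compound 4 (0.01 log units; that floor lies within the scatter), that is, none beyond the scatter. Compound 4 is accordingly estimated at 160000 nM in this assay, within 70000 nM to 400000 nM, with a fair chance that the assay again reports only a limit.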

Compound 4, half-maximal cytotoxic concentration: > 158000 nM
Compound 4 was reported as a limit; the forecaster's own chance of this, stated with the estimate: 60%; the middle value does not contradict the limit.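

In this assay compound 4 gives > 158000 nM, which is a limit of the assay, so replacing methoxy with propyl on a saturated chain carbon, two bonds along the chain from an amide-type nitrogen, still yields no number. Of the amide substituents shown, phenyl, 2-methoxyethyl and now pentyl all end at a limit, and 4-chlorophenyl in compound 2 goes against this as the only one that returns a number. The one readable new step is an at least 1.7-fold higher number from compound 2 to compound 4 (0.24 log units; that floor lies within the scatter), while the steps from compound 1 and from compound 3 to compound 4 cannot be read, each having a limit at both ends: the limit of > 158000 nM in this assay, at which 1 of the 4 values shown sits.

From the compounds shown here alone, whether methoxy and propyl differ at all at this place remains open, as does any ordering among compound 1, compound 3 and compound 4. Also open, going by these compounds, is whether an amine or a carboxylic acid at the end of the chain, or a longer chain such as octyl, would bring the result down to a number in this assay.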